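Pyridinyl for Thiophenyl on a Pyrazole Chalcone Core

The source may hold more compounds than are shown below. What is called first, only, known or untested is meant among the compounds shown, and "the series" means these compounds.

Measured compounds:
compound 1, `O=C(/C=C/c1cn(-c2ccccc2)nc1-c1ccsc1)c1ccccc1`, 5100 nM
compound 2, `COc1cc(C(=O)/C=C/c2cn(-c3ccccc3)nc2-c2ccsc2)cc(OC)c1OC`, 3200 nM
compound 3, `O=C(/C=C/c1cn(-c2ccccc2)nc1-c1cccnc1)c1ccccc1`, 2000 nM

All three were tested in a functional assay on HCT-116 cells (Homo sapiens) for inhibition, read by sulforhodamine B assay, with a stated time of 72 h; on this read-out higher numbers stand for weaker inhibition and lower numbers for stronger inhibition. Compound 1 and compound 3 share one core and differ in a single spot: pyridin-3-yl in place of thiophen-3-yl on an aromatic carbon. This step gave a 2.6-fold lower number from compound 1 to compound 3 (0.41 log units; beyond the scatter). Compound 2 carries a different core from compound 1; the difference between the two cores is not broken down here. In this assay the values of compound 2 and compound 1 lie within the usual scatter of each other, as do those of compound 2 and compound 3.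

Compound 4, `COc1cc(C(=O)/C=C/c2cn(-c3ccccc3)nc2-c2cccnc2)cc(OC)c1OC`, has not yet been measured. It differs from compound 2 in the same way that compound 3 differs from compound 1: pyridin-3-yl in place of thiophen-3-yl on an aromatic carbon. The two places match word for word, so this is the same change on another core. On the basis of a 2.6-fold lower number from compound 1 to compound 3 (0.41 log units; beyond the scatter), compound 4 is expected to give a step of a 2.5-fold lower number from compound 2 to compound 4 (0.39 log units; beyond the scatter) from compound 2 in this assay. The estimate for compound 4 is 1300 nM, with a range from 500 nM to 3500 nM.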

Compound 4, half-maximal inhibitory concentration: 8600 nM
Compound 4: middle estimate off by 6.6-fold (0.82 log units), on the low side, and the stated range ends below it.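

On the core of compound 2, putting pyridin-3-yl in place of thiophen-3-yl in this assay gave a 2.7-fold higher number from compound 2 to compound 4 (0.43 log units; beyond the scatter), so the swap weakened inhibition here, whereas it strengthened inhibition on the core of compound 1. The two results therefore point in opposite directions, and the gap between them is larger than repeated measurements would explain: the same change on two cores in this assay, a 2.6-fold lower number (0.41 log units; beyond the scatter) from compound 1 to compound 3 and a 2.7-fold higher number (0.43 log units; beyond the scatter) from compound 2 to compound 4, 6.9-fold (0.84 log units) apart, beyond the scatter of two such steps This shows that, for these two cores, the effect of this change cannot simply be carried from one to the other, but it does not show why the direction reverses, and a single pair on each core cannot reveal which result is more typical of the series.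

The compounds shown leave open how other groups in this place, such as furan-3-yl or a simple amine, would behave on these two cores. Also open, as far as these compounds go, is whether the same swap on a third core would follow the step seen on the core of compound 1 or the step seen on the core of compound 2.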